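Swapping Fluoro for Nitro on a Second Amine Tail

This account rests on a few compounds, and the source may have more. Where it says the series, first, only, none or still open, it means among the compounds named here.

Compound 1, `COc1cc2c(Oc3ccc(NC(=O)c4nn(-c5ccc(F)cc5)c(=O)c5ccccc45)cc3F)ccnc2cc1OCCCN1CCN(C)CC1`, in a functional assay on MKN-45 cells (Homo sapiens) for cytotoxicity, read by MTT assay, with a stated time of 72 h (on this read-out higher numbers stand for weaker inhibition and lower numbers for stronger inhibition), gives 150 nM.
Compound 2, `COc1cc2c(Oc3ccc(NC(=O)c4nn(-c5ccc([N+](=O)[O-])cc5)c(=O)c5ccccc45)cc3F)ccnc2cc1OCCCN1CCN(C)CC1`, in this assay gives 1320 nM.
Compound 3, `COc1cc2c(Oc3ccc(NC(=O)c4nn(-c5ccc(F)cc5)c(=O)c5ccccc45)cc3F)ccnc2cc1OCCCN1CCC(C)CC1`, in this assay gives 130 nM.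

Compound 3 has the lowest number of the three in this assay; its nearest neighbour is compound 1, within the scatter, so the two cannot be told apart, while compound 2 sits well beyond the scatter from both. Compound 4, `COc1cc2c(Oc3ccc(NC(=O)c4nn(-c5ccc([N+](=O)[O-])cc5)c(=O)c5ccccc45)cc3F)ccnc2cc1OCCCN1CCC(C)CC1`, is compound 3 with one change: nitro in place of fluoro on an aromatic carbon. The same swap has been made once before, on the shared core carrying the other amine tail, where it gave an 8.8-fold higher number from compound 1 to compound 2 (0.94 log units; beyond the scatter). The other measured step, a 1.2-fold lower number from compound 1 to compound 3 (0.06 log units; within the scatter), shows that exchanging the amine tail on its own stayed within the scatter, so nothing in the data suggests that the tail would alter the response to the nitro swap. The expectation for compound 4 is therefore a step of about the same size and in the same direction as before, an 8.8-fold higher number from compound 3 to compound 4 (0.95 log units; beyond the scatter). Compound 4 is estimated to give 1150 nM in this assay, with a likely range from 400 nM to 3500 nM.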

Compound 4, half-maximal inhibitory concentration: 1150 nM
Compound 4: the middle estimate sits on the measured number at the digits printed; measured number inside the range.
By their numbers in this assay, from the lowest: compounds 3 and 1 (each within the scatter of the next); then compounds 4 and 2 (each within the scatter of the next).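

On the 4-methylpiperidin-1-yl tail, the change from 4-fluorophenyl to 4-nitrophenyl gives an 8.8-fold higher number from compound 3 to compound 4 (0.95 log units; beyond the scatter), so a step that rested on one pair now rests on two, and the two steps match: the same change on two cores in this assay, an 8.8-fold higher number (0.94 log units; beyond the scatter) from compound 1 to compound 2 and an 8.8-fold higher number (0.95 log units; beyond the scatter) from compound 3 to compound 4, 1.0-fold (0.00 log units) apart, within the scatter of two such steps

The fourth compound also gives the tail exchange a second reading, this time with nitro on the aromatic ring in place of fluoro, where it gives a 1.1-fold lower number from compound 2 to compound 4 (0.06 log units; within the scatter) and again stays within the scatter: the same change on two cores in this assay, a 1.2-fold lower number (0.06 log units; within the scatter) from compound 1 to compound 3 and a 1.1-fold lower number (0.06 log units; within the scatter) from compound 2 to compound 4, 1.0-fold (0.00 log units) apart, within the scatter of two such steps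

Across these four compounds in this assay, the two changes therefore read as separate, with the group para to a large group moving the number beyond the scatter and the choice between these two tails leaving it within the scatter.

The compounds shown carry only fluoro or nitro at this position, so they cannot tell how a chloro, a methoxy or an amine there would read. With just two tails in hand, they also leave open whether the nitro step would keep its size with a morpholin-4-yl tail or a longer chain carrying the amine.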